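Adding a Third Methoxy: From Compound 3 to Compound 4

The compounds below may be only part of what the source reports. "The series", "measured", "known", "first", "only" and "open" are said of these compounds alone.

Measured in a functional assay on 786-0 cells (Homo sapiens) for inhibition, read by sulforhodamine B assay, with a stated time of 48 h; a lower number here means a stronger inhibitor of growth, a higher number a weaker inhibitor of growth:
Compound 1 `O=C1C=COC(/C=C/c2ccc(C(F)(F)F)cc2)C1`: 39.6 uM
Compound 2 `COc1ccc(/C=C/C2CC=CC(=O)O2)cc1`: 21.6 uM
Compound 3 `COc1ccc(/C=C/C2CC=CC(=O)O2)cc1OC`: 10.9 uM

Among these three, compound 3 gives the lowest number in this assay. Its nearest neighbour is compound 2, whose number is higher by the step of a 2.0-fold lower number from compound 2 to compound 3 (0.30 log units; within the scatter), which falls within the scatter. Compound 1 stands furthest away, and its number is higher than that of compound 3 by an amount beyond the scatter.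

Compound 4 `COc1cc(/C=C/C2CC=CC(=O)O2)cc(OC)c1OC` has not yet been measured. It differs from compound 3 by a single change: methoxy in place of hydrogen on an aromatic carbon.

Within the data shown here, the only measured step that speaks to this change is the one from compound 2 to compound 3, a 2.0-fold lower number from compound 2 to compound 3 (0.30 log units; within the scatter), where a methoxy also replaced a hydrogen on an aromatic carbon; that step did not leave the scatter. On that basis the step of a 1.4-fold lower number from compound 3 to compound 4 (0.13 log units; within the scatter) is expected to be small, with a slight lean toward a lower number but quite possibly no change beyond the scatter. Compound 4 is therefore estimated at 8 uM, with a likely range from 3 uM to 22 uM in this assay.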

Compound 4, concentration for growth inhibition (reported as GI): 18.5 uM
For compound 4 the middle estimate is 2.3-fold (0.36 log units) below the measured one; measured number inside the range.
By their numbers in this assay, from the lowest: compounds 3, 4, 2 and 1 (each within the scatter of the next, the first and the last beyond it).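

In this assay, a methoxy placed on this aromatic carbon, ortho to a methoxy group, meta to a group of 9 heavy atoms and meta to a methoxy group, gives a 1.7-fold higher number from compound 3 to compound 4 (0.23 log units; within the scatter), so this position accepts the added group without a change that can be told apart from the scatter. The same replacement on another aromatic carbon gave a 2.0-fold lower number from compound 2 to compound 3 (0.30 log units; within the scatter), which means that two steps of this kind now stand side by side, neither leaves the scatter, and no consistent direction can be read for adding a methoxy to this aromatic ring. Nothing measured here bears on why the step from the third methoxy came out as it did.

The compounds shown leave open whether a different group on this aromatic carbon, such as a hydroxyl, an amine or a carboxylic acid, would move the number beyond the scatter. They also leave open whether a longer chain on the oxygen, such as ethoxy in place of methoxy, would do so.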